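The compounds below may be only part of what the source reports. "The series", "measured", "known", "first", "only" and "open" are said of these compounds alone.

In a physicochemical assay for solubility, tested at 272 nM (on this read-out higher numbers stand for higher solubility and lower numbers for lower solubility), compound 1 `CCCCCCCCCCCCCC(=O)OC(COCCCCCCCCCCCC)COP(=O)(O)OP(=O)(O)OC[C@H]1OC(n2ccc(N)nc2=O)[C@@H](O)[C@@H]1O` gives > 146000000 nM, which is a limit of the assay rather than a number. Compound 2 `CCCCCCCCCCCCCCOCC(COP(=O)(O)OP(=O)(O)OC[C@H]1OC(n2ccc(N)nc2=O)[C@@H](O)[C@@H]1O)OC(=O)CCCCCCCCCCCCC` likewise reaches only a limit, > 121000000 nM. Compound 3 `CCCCCCCCCCCCCCCCOCC(COP(=O)(O)OP(=O)(O)OC[C@H]1OC(n2ccc(N)nc2=O)[C@@H](O)[C@@H]1O)OC(=O)CCCCCCCCCCC` also gives a limit, > 132000000 nM. The step that the two limits leave unreadable from compound 1 to compound 2 is left unreadable by the two limits, so compound 3 stands, as do the other two compounds, at a limit and not at a measured number. Compound 4 `CCCCCCCCCCCCCCCCOCC(COP(=O)(O)OP(=O)(O)OC[C@H]1OC(n2ccc(N)nc2=O)[C@@H](O)[C@@H]1O)OC(=O)CCCCCCCCCCCCC` differs from compound 3 by ethyl in place of hydrogen on a saturated chain carbon, ten or more bonds along the chain from a carbonyl carbon. For the measured compounds named here, the only measured step of this kind, a step that the two limits leave unreadable from compound 1 to compound 2, offers no size, so the expected step that the limit leaves unreadable from compound 3 to compound 4 cannot be given a direction beyond a further limit. Compound 4 is therefore expected at 150000000 nM, within 100000000 nM to 220000000 nM, most probably reported again as a limit.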

Compound 4, solubility: > 107000000 nM
Compound 4: a limit, no number; the forecaster's own chance of this, stated with the estimate: 90%; the middle value does not contradict the limit.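

In this assay compound 4, like compounds 1, 2 and 3, stands at a limit and not at a number, so no step among these compounds can be read. From the compounds shown here alone, the true values of all four, and any effect of the chain differences on them, remain open.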